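A few compounds are considered here, and "the series" means these few. Any claim that something is new, unique, unknown or untested is made for them only; others in the source may bear on it.

Compound 1 `O=C(Nc1cccc(-c2oc3cc(-c4ccc(F)cc4)ccc3c(=O)c2O)c1)c1ccc(Cl)nc1` gives 4080 nM in a functional assay on HeLa cells (Homo sapiens) for antiproliferative activity, read by CCK-8 assay, with a stated time of 72 h; on this read-out higher numbers stand for weaker inhibition and lower numbers for stronger inhibition. Compound 2 `O=C(Nc1cccc(-c2oc3cc(-c4ccc(F)cc4)ccc3c(=O)c2O)c1)c1ccc(-c2ccccc2)cc1` reports only > 100000 nM in this assay, which is a limit of the assay and not a number. Compound 2 therefore stands at the limit of > 100000 nM in this assay, at which 1 of the 2 values shown sits, reached through an at least 24-fold higher number from compound 1 to compound 2 (1.38 log units; beyond the scatter). Compound 3 `CCCc1ccc(C(=O)Nc2cccc(-c3oc4cc(-c5ccc(F)cc5)ccc4c(=O)c3O)c2)cc1` carries propyl in place of phenyl on an aromatic carbon, so 4-phenylphenyl gives way to 4-propylphenyl. Within the data shown here, only that one measured step bears on this change; it was large and in the weakening direction, and compound 3 undoes part of it, so a partial recovery is expected, though a limit value stays possible. Compound 3 is estimated at 30000 nM (range 8000 nM to 100000 nM), an expected at least 3.3-fold lower number from compound 2 to compound 3 (0.52 log units; beyond the scatter).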

Compound 3, half-maximal inhibitory concentration: 8790 nM
Estimate against measurement, compound 3: 3.4-fold (0.53 log units) above; the measured number falls inside the stated range.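

In this assay, propyl in place of phenyl brings the series back from the limit to a measurable number, an at least 11-fold lower number from compound 2 to compound 3 (1.05 log units; beyond the scatter). The amide position therefore tolerates a benzene ring with a group para to the amide carbonyl, since 4-propylphenyl in place of 6-chloropyridin-3-yl costs only a modest step, a 2.2-fold higher number from compound 1 to compound 3 (0.33 log units; beyond the scatter). The value of compound 2 remains a limit of the assay, not a number: the limit of > 100000 nM in this assay, at which 1 of the 3 values shown sits.

Open, from the compounds shown here alone, is whether the ring of the leaving phenyl or the size of the group governs this drop. A methyl group, a longer chain such as pentyl, or a carboxylic acid at the same place would separate these readings.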